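The source may hold more compounds than are shown below. What is called first, only, known or untested is meant among the compounds shown, and "the series" means these compounds.

Measured so far in a functional assay on MCF7 cells (Homo sapiens) for cytotoxicity, read by MTT assay, with a stated time of 96 h; on this read-out lower numbers stand for stronger inhibition and higher numbers for weaker inhibition:
- compound 1 `COc1cc(C(=O)c2cn(-c3ccccc3Cl)cc2-c2ccccc2)cc(OC)c1OC`: 1800 nM
- compound 2 `COc1cc(C(=O)c2cn(-c3ccccc3[N+](=O)[O-])cc2-c2ccccc2)cc(OC)c1OC`: 5000 nM
- compound 3 `COc1cc(C(=O)c2cn(-c3ccccc3)cc2-c2cccc(Br)c2)cc(OC)c1OC`: 950 nM

Compound 3 at 950 nM lies within the scatter of compound 1 at 1800 nM. The number of compound 2 at 5000 nM stands above that of compound 3, beyond the scatter.

The next step leads to compound 4 `COc1cccc(-c2cn(-c3ccccc3)cc2C(=O)c2cc(OC)c(OC)c(OC)c2)c1`, which has methoxy in place of bromo on an aromatic carbon, 3-bromophenyl to 3-methoxyphenyl: methoxy in place of bromo on an aromatic carbon.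

For the measured compounds named here, no measured pair tests this exchange directly. Going by the values given here, the only measured step, a 2.8-fold higher number from compound 1 to compound 2 (0.44 log units; beyond the scatter), is modest and comes from nitro in place of chloro on an aromatic carbon, a different exchange at a different site. It suggests that a single substituent exchange in this small set can shift the number modestly, but it gives no direction for bromo to methoxy. In this assay, from the compounds shown here alone, no shift beyond the scatter is therefore expected, although a modest move either way remains open.

The expected step is a 1.1-fold higher number from compound 3 to compound 4 (0.02 log units; within the scatter). The estimated value for compound 4 is 1000 nM, with an expected range of 350 nM to 3000 nM.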

Compound 4, half-maximal inhibitory concentration: 180 nM
Beside the measured number, compound 4's estimate is 5.6-fold (0.74 log units) above it; the measured number lies below the stated range.
By their numbers in this assay, from the lowest: compound 4; then compounds 3 and 1 (each within the scatter of the next); then compound 2.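

In this assay, for the compounds shown here, the exchange of bromo for methoxy on an aromatic carbon, 3-bromophenyl to 3-methoxyphenyl, gives a 5.3-fold lower number from compound 3 to compound 4 (0.72 log units; beyond the scatter), the first measured step at this position and one that lies beyond the scatter. The substituent at this place therefore matters to the read-out, and the exchange of one heavy atom for two, with one hydrogen-bond acceptor entering, goes with a lower number; the earlier step, a 2.8-fold higher number from compound 1 to compound 2 (0.44 log units; beyond the scatter), belongs to a different exchange at a different site and said nothing about this one. No measurement at hand accounts for the shift, so the step stands as an observation without an explanation.

One exchange at this position cannot show whether the lower number is particular to methoxy, and a hydroxy group, an amine or a longer chain such as ethoxy on the same carbon would test how far the trend extends. From the compounds shown here alone, it also remains open whether methoxy gives a similar step when chloro or nitro is present on the other phenyl group, as in compound 1 and compound 2.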